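Methyl Gives Way to Methoxy on the Phenyl Ring

This account rests on a few compounds, and the source may have more. Where it says the series, first, only, none or still open, it means among the compounds named here.

Compound 1 `COc1ccccc1Oc1c(N)nc(-c2ccccc2)nc1Cl` gives 4610 nM in a functional assay on B16 cells (Mus musculus) for cytotoxicity, read by CCK-8 assay, with a stated time of 24 h; on this read-out higher numbers stand for weaker inhibition and lower numbers for stronger inhibition. Compound 2 `COc1ccccc1Oc1c(N)nc(-c2cccc(C)c2)nc1Cl` gives 13100 nM in this assay, the higher of the two numbers measured; the step of a 2.8-fold higher number from compound 1 to compound 2 (0.45 log units; beyond the scatter) goes with methyl in place of hydrogen on an aromatic carbon. Compound 3 `COc1cccc(-c2nc(N)c(Oc3ccccc3OC)c(Cl)n2)c1` differs from compound 2 by methoxy in place of methyl on an aromatic carbon. Going by the values given here, the only measured step that bears on this change is a 2.8-fold higher number from compound 1 to compound 2 (0.45 log units; beyond the scatter), a modest rise; how methoxy compares with methyl at that carbon is untested here. Compound 3 is therefore expected near 11000 nM, within 4000 nM to 35000 nM. The expected step is a 1.2-fold lower number from compound 2 to compound 3 (0.08 log units; within the scatter), nothing beyond the scatter.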

Compound 3, half-maximal inhibitory concentration: 23600 nM
Beside the measured number, compound 3's estimate is 2.1-fold (0.33 log units) below it; the range from low to high includes it.
By their numbers in this assay, from the lowest: compound 1; then compounds 2 and 3 (each within the scatter of the next).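

In this assay methoxy in place of methyl at this carbon gives a 1.8-fold higher number from compound 2 to compound 3 (0.26 log units; within the scatter) and so does not separate the two groups. Set against hydrogen, methoxy gives a 5.1-fold higher number from compound 1 to compound 3 (0.71 log units; beyond the scatter) and this shows that the weaker inhibition seen with methyl on this carbon, meta to a large group, is not confined to methyl. No measured evidence accounts for this. From the compounds shown here alone, whether an amine or a carboxylic acid at this carbon would follow the same course stays open, as does whether methoxy would do so on another carbon of the ring.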